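Swapping the aryl ketone substituent in a coumarin hydrazide series

The compounds below may be only part of what the source reports. "The series", "measured", "known", "first", "only" and "open" are said of these compounds alone.

Measured so far:
compound 1 `Cc1ccc(OCC(=O)NNC(=O)c2cc3ccccc3oc2=O)c(C(=O)c2ccccc2Br)c1` gives 10000 nM
compound 2 `Cc1ccc(OCC(=O)NNC(=O)c2cc3ccccc3oc2=O)c(C(=O)c2ccccc2Cl)c1` gives 53800 nM
compound 3 `Cc1ccc(OCC(=O)NNC(=O)c2cc3ccccc3oc2=O)c(C(=O)c2ccc(Cl)cc2)c1` gives 59100 nM

These three share one core and differ only in the aryl group attached to the ketone. In a functional assay on DLA cells (Mus musculus) for cytotoxicity, read by MTT assay, with a stated time of 48 h (on this read-out lower numbers stand for stronger inhibition and higher numbers for weaker inhibition), compound 2 stands second highest of the three numbers; it sits close to compound 3 (a 1.1-fold higher number from compound 2 to compound 3 (0.04 log units; within the scatter)) and far from compound 1 (a 5.4-fold higher number from compound 1 to compound 2 (0.73 log units; beyond the scatter)). Compound 4 `Cc1ccc(C(=O)c2cc(C)ccc2OCC(=O)NNC(=O)c2cc3ccccc3oc2=O)cc1` is not yet measured; it differs from compound 2 by 4-methylphenyl in place of 2-chlorophenyl on a carbonyl carbon. Within the data shown here, no measured step exchanges a halogen for a methyl group, so the only guidance is that moving the chloro within the ring changed little, while the bromo-to-chloro exchange was modest. Compound 4 is therefore expected to stay near compound 2, with an estimated step of a 1.1-fold lower number from compound 2 to compound 4 (0.03 log units; within the scatter). The estimate for compound 4 is 50000 nM, between 15000 nM and 150000 nM.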

Compound 4, half-maximal inhibitory concentration: 84600 nM
Beside the measured number, compound 4's estimate is 1.7-fold (0.23 log units) below it, within the range that was stated.
By their numbers in this assay, from the lowest: compound 1; then compounds 2, 3 and 4 (each within the scatter of the next).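

In this assay, among these compounds, the first exchange of chloro for methyl gives a 1.4-fold higher number from compound 3 to compound 4 (0.16 log units; within the scatter) and so does not separate these two compounds, while the change of ring gives a 1.6-fold higher number from compound 2 to compound 4 (0.20 log units; within the scatter), likewise without a readable difference. Compound 1 now stands apart from a third compound (an 8.5-fold higher number from compound 1 to compound 4 (0.93 log units; beyond the scatter)), so 2-bromophenyl on a carbonyl carbon is the only group shown that gives a clearly lower number. No measurement shown explains this difference.

The compounds shown leave open whether bromo itself sets compound 1 apart. They also leave open what an aminophenyl or carboxyphenyl group on this carbonyl carbon would do.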